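This account rests on a few compounds, and the source may have more. Where it says the series, first, only, none or still open, it means among the compounds named here.

Measured compounds:
compound 1, `CC(C)(C)c1ccc(-c2nc3c(N4CCN(Cc5cccc6nccnc56)CC4)cccc3[nH]2)cc1`, 12.2 nM
compound 2, `CC(C)(C)OC(=O)N[C@@H](Cn1cc(CN2CCN(c3cccc4[nH]c(-c5ccc(C(C)(C)C)cc5)nc34)CC2)nn1)C(=O)O`, 186 nM

In a functional assay on cells for antagonist activity at Gonadotropin-releasing hormone receptor (Homo sapiens), read by FLIPR and calcium flux, with a stated time of 15 min (on this read-out lower numbers stand for stronger inhibition and higher numbers for weaker inhibition), compound 1 gives 12.2 nM, the lowest of the two numbers recorded. Compound 2 gives 186 nM in this assay, a higher number that lies beyond the usual scatter, so compound 1 is the stronger antagonist of the pair on these data.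

Compound 3, `CC(C)(C)c1ccc(-c2nc3c(N4CCN(Cc5cn(-c6ccc(F)cc6)nn5)CC4)cccc3[nH]2)cc1`, has not yet been measured. It differs from compound 1 in a single place: 1-(4-fluorophenyl)-1H-1,2,3-triazol-4-yl in place of quinoxalin-5-yl on a saturated chain carbon bound to an amine nitrogen in a ring. The fused bicyclic group is exchanged for a five-membered ring carrying a fluorinated phenyl, while the shared core and the ring amine stay unchanged. Going by the values given here, no step between two measured compounds shows this exact exchange, so the estimate rests on compound 1 alone. A moderate move toward a higher number is expected, since compound 2 with a different triazole substituent gives 186 nM. For compound 3 the expected step is a 3.3-fold higher number from compound 1 to compound 3 (0.52 log units; beyond the scatter), and the estimated value in this assay is 40 nM, within a range from 10 nM to 160 nM.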

Compound 3, inhibition constant: 410 nM
The estimate for compound 3 lay 10-fold (1.01 log units) below the measured number; measured number outside the range, above it.
By their numbers in this assay, from the lowest: compound 1; then compound 2; then compound 3.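

In this assay the exchange of quinoxalin-5-yl for 1-(4-fluorophenyl)-1H-1,2,3-triazol-4-yl on a saturated chain carbon bound to an amine nitrogen in a ring brings a 34-fold higher number from compound 1 to compound 3 (1.53 log units; beyond the scatter) and so counts as a large loss of strength. This position is therefore sensitive to which group it carries. Both groups hold two aromatic rings and neither has a hydrogen-bond donor or a net charge, so a match in those counts is not enough to keep the strength, and nothing measured here explains the loss. The compounds shown do not separate the part played by the triazole ring from that of the 4-fluorophenyl on it. A quinoline or a plain phenyl at this place would show how much of the strength of compound 1 depends on the quinoxalin-5-yl itself.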